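The source may hold more compounds than are shown below. What is called first, only, known or untested is meant among the compounds shown, and "the series" means these compounds.

Compound 2 `CSCC1C2CCC(O2)C1C/C=C\CCCC(=O)O` is measured in a functional assay on a cell-free system (plasma) with thromboxane A2 receptor (Homo sapiens) as the target (on this read-out higher numbers stand for weaker inhibition and lower numbers for stronger inhibition), at 38000 nM. Among the compounds with values here, its only measured neighbour is compound 1 `O=C(O)CCC/C=C\CC1C2CCC(O2)C1CSCCOc1ccccc1`, which in this assay gives 20000 nM; the step of a 1.9-fold higher number from compound 1 to compound 2 (0.28 log units; within the scatter) is the whole comparison available, so compound 2 stands on level ground with compound 1 rather than apart from it. Compound 3 `O=C(O)CCC/C=C\CC1C2CCC(O2)C1CSc1ccccc1` differs from compound 2 by phenyl in place of methyl on a sulfur. Within the data shown here, no measured step covers this change directly; the step of a 1.9-fold higher number from compound 1 to compound 2 (0.28 log units; within the scatter) concerns a different group on the carbon bound to the sulfur and lies within the scatter, so it gives no firm guide. For compound 3 a step of a 2.5-fold lower number from compound 2 to compound 3 (0.40 log units; beyond the scatter) is expected, giving an estimated 15000 nM with a range from 4000 nM to 50000 nM.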

Compound 3, half-maximal inhibitory concentration: 13000 nM
Compound 3: middle estimate off by 1.2-fold (0.06 log units), on the high side, within the range that was stated.
By their numbers in this assay, from the lowest: compounds 3, 1 and 2 (each within the scatter of the next, the first and the last beyond it).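

Phenyl in place of methyl on the sulfur gives a 2.9-fold lower number from compound 2 to compound 3 (0.47 log units; beyond the scatter) in this assay, the first step here to clear the scatter, so this position does respond to the group on the sulfur. Phenyl and 2-phenoxyethyl on the sulfur cannot be told apart, given a 1.5-fold lower number from compound 1 to compound 3 (0.19 log units; within the scatter) within the scatter, so phenyl directly on the sulfur does as well as the longer chain. Nothing measured here explains the step.

Still open, as far as these compounds go, is whether a phenyl ring carrying a chlorine or an amine would move the number further. Also open, from the compounds shown here alone, is what an oxygen in place of the sulfur would do.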